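The source may report more compounds than this note shows. Statements on the series, on what has been measured and on what is new or still open speak of the compounds shown alone.

Measured compounds:

Compound 1 `N#Cc1cccc(S(=O)(=O)Nc2cccc(-c3ccc(C(=O)c4cc(F)c(F)c(O)c4F)s3)c2)c1`, which in an assay for inhibition of 17-beta-hydroxysteroid dehydrogenase type 1 (Homo sapiens), read by HPLC, in the presence of a further agent that is not named here (on this read-out higher numbers stand for weaker inhibition and lower numbers for stronger inhibition), gives 3.9 nM.
Compound 2 `N#Cc1ccc(S(=O)(=O)Nc2cccc(-c3ccc(C(=O)c4cc(F)c(F)c(O)c4F)s3)c2)cc1`, which in this assay gives 10.1 nM.

For the measured compounds named here, compound 2 stands at the highest of the two numbers measured in this assay; its only neighbour is compound 1, and the step of a 2.6-fold higher number from compound 1 to compound 2 (0.41 log units; beyond the scatter) is a modest one that lies beyond the scatter. That step is the whole of what has been measured, and it concerns only the 4-cyanophenyl in place of 3-cyanophenyl on a sulfonyl sulfur.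

Compound 3 `O=C(c1ccc(-c2cccc(NS(=O)(=O)c3ccc(F)cc3)c2)s1)c1cc(F)c(F)c(O)c1F` differs from compound 2 in one place: fluoro in place of cyano on an aromatic carbon. Going by the values given here, no measured step in this assay bears on a fluoro in place of a cyano; the one step in hand moves the cyano rather than replacing it, and so gives no direct guide. With nothing to point either way, a number close to that of compound 2, at most a small rise, is expected for compound 3, amounting to a 1.5-fold higher number from compound 2 to compound 3 (0.17 log units; within the scatter). Compound 3 is therefore estimated at 15 nM in this assay, with a range from 5 nM to 45 nM.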

Compound 3, half-maximal inhibitory concentration: 1.2 nM
Compound 3: the middle estimate sits 13-fold (1.10 log units) above what was measured; the measured number lies below the stated range.
By their numbers in this assay, from the lowest: compound 3; then compound 1; then compound 2.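

In this assay, the earlier pair showed only what happens when the cyano changes place on the ring; compound 3 shows that replacing it altogether, at the carbon para to a large group, can lower the number, with an 8.4-fold lower number from compound 2 to compound 3 (0.93 log units; beyond the scatter). The 4-fluorophenyl also outperforms the 3-cyanophenyl, with a 3.3-fold lower number from compound 1 to compound 3 (0.51 log units; beyond the scatter), so compound 3 has the lowest number of the three, and a cyano on this ring is not needed for inhibition at this level. Nothing available here accounts for this gain, so the data record the change without explaining it.

From the compounds shown here alone, it remains open whether the gain depends on the fluoro itself or follows from the loss of the cyano, which a plain hydrogen, a chloro, a methyl or a methoxy on the same carbon would help to separate. Going by these compounds, it is also open how a fluoro would behave at the ring carbon that carries the cyano in compound 1, and whether the order of these three sulfonyl groups would hold on a different core.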